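Swapping the Group on a Sulfonamide Nitrogen

The compounds below may be only part of what the source reports. "The series", "measured", "known", "first", "only" and "open" are said of these compounds alone.

Of the compounds shown here, three from one study have been measured in a physicochemical assay for lipophilicity, at pH 7.4; a higher number here means a more lipophilic compound, a lower number a more polar compound. Compound 1 (`CC(C)CN(Cc1ccccc1C(F)(F)F)S(=O)(=O)c1ccc2c(c1)C(O)CC(C1CCOCC1)O2`) gives 4.23. Compound 2 (`CCc1ccc(N(CC(C)C)S(=O)(=O)c2ccc(OCC3CCOCC3)c(CN)c2)cc1`) gives 3.25 in this assay, and compound 3 (`CCc1ccc(N(CC(C)C)S(=O)(=O)c2ccc3c(c2)C(C)CC(C2CCOCC2)O3)cc1`) gives 5.71. Among these three numbers compound 1 stands second highest: its nearest neighbour is compound 2, whose number is lower by more than the usual scatter, and the furthest is compound 3, whose number is higher, again beyond the scatter. No two of the measured compounds differ in only one place, so no single step can be read directly from them.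

Compound 4 (`CC(C)CN(c1cc2ccccc2s1)S(=O)(=O)c1ccc2c(c1)C(O)CC(C1CCOCC1)O2`) shares its core with compound 1 and differs from it in one place: 1-benzothiophen-2-yl in place of 2-(trifluoromethyl)benzyl on a sulfonamide nitrogen. Compound 4 has not yet been measured in this assay.

For the move from compound 1 to compound 4 in this assay, no shift beyond the scatter is expected, at most a slight rise. The anchor for this is compound 1, which gives 4.23 in this assay. The expected value for compound 4 is 4.3, with a range from 3.8 to 4.8. This corresponds to an expected step of a number 0.07 log units higher from compound 1 to compound 4 (within the scatter).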

Compound 4, distribution coefficient: 3.92
For compound 4 the middle estimate is 0.38 log units above the measured one, and the stated range covers the measured number.
By their numbers in this assay, from the lowest: compound 2; then compound 4; then compound 1; then compound 3.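

Among these compounds, this is the first pair in the set that differs in only one place, so a change on the sulfonamide nitrogen can now be read directly: in this assay, 1-benzothiophen-2-yl in place of 2-(trifluoromethyl)benzyl gives a number 0.31 log units lower from compound 1 to compound 4 (beyond the scatter). The step is modest, yet the two groups differ clearly in what is counted: the one that leaves has a single six-membered aromatic ring and three fluorine atoms, while the one that enters adds a five-membered aromatic ring containing sulfur and has no fluorine. Nothing available assigns the step to any one of these differences, and no independent measurement bears on its cause.

The compounds shown leave open how a plain benzyl group would compare on this nitrogen, a swap that would change only the trifluoromethyl group of compound 1 and so help separate its contribution from that of the rest of the group. They also leave open whether a carboxylic acid or an amine carried on this nitrogen would move the number much further than this exchange between two aromatic groups did.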